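The source may hold more compounds than are shown below. What is called first, only, known or untested is meant among the compounds shown, and "the series" means these compounds.

Measured compounds:
- compound 1, `COc1ccc(C2=NN(c3ccccc3)C(c3ccc(C)cc3)C2S(=O)(=O)CC2=NCCO2)cc1`: 62.5%
- compound 2, `O=S(=O)(CC1=NCCO1)c1c(-c2ccccc2)nn(-c2ccccc2)c1-c1ccccc1`: 55.6%
- compound 3, `O=S(=O)(CC1=NCCS1)C1C(c2ccccc2)=NOC1c1ccccc1`: "not active" (no number reported)

In a functional assay, tested at 50 ug/mL (on this read-out lower numbers stand for a weaker effect and higher numbers for a stronger effect at the one concentration tested), compound 1 gives 62.5% and compound 2 gives 55.6%; these two values lie within the scatter of each other, so no order between them is claimed. Among the measured compounds shown here, compound 3 stands apart: in this assay compound 3 was recorded only as "not active" (no number reported), without a single number, so no step from it can be computed.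

Compound 4, `O=S(=O)(CC1=NCCO1)C1C(c2ccccc2)=NOC1c1ccccc1`, differs from compound 3 in one place: a group of 5 heavy atoms (3 carbon, 1 nitrogen, 1 oxygen; one five-membered non-aromatic ring with 2 hetero atoms) in place of a group of 5 heavy atoms (3 carbon, 1 nitrogen, 1 sulfur; one five-membered non-aromatic ring with 2 hetero atoms), on a saturated chain carbon bound to a sulfonyl sulfur. The group that enters is the same ring that compounds 1 and 2 carry on their different cores, both of which show measurable effect in this assay.

For the measured compounds named here, no measured step bears on this change. Going by the values given here, the expectation is an increase beyond the scatter in this assay for compound 4 relative to the inactive compound 3, but smaller than the effect of compounds 1 and 2, since the core of compound 3 is shared with no measured active compound. Compound 4 is expected to give about 25%, in the range 0% to 55%. A result like that recorded for compound 3, "not active" (no number reported), remains a real possibility.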

Compound 4, a percentage reported as activity, at one concentration (the size of the read-out at that concentration, not a potency): 51.7%
For compound 4 the middle estimate is 26.7 percentage points below the measured one; the measured number falls inside the stated range.
By their numbers in this assay, from the lowest: compounds 4, 2 and 1 (each within the scatter of the next, the first and the last beyond it).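

Among the compounds shown here, compound 3 has no number in this assay, so no step to compound 4 can be read. The compounds shown leave open whether the same ring exchange on the cores of compound 1 or compound 2 would change the read-out. No available evidence bears on this result.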